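Swapping the Benzyl Ring Substituent in a Nitrile Series

The source may report more compounds than this note shows. Statements on the series, on what has been measured and on what is new or still open speak of the compounds shown alone.

Compound 1 `COc1ccc(Nc2nc(SCc3cn(Cc4ccccc4Cl)nn3)nc(-c3ccccc3)c2C#N)cc1` gives 3990 nM in a functional assay on B16-F10 cells (Mus musculus) for inhibition, read by MTT assay, with a stated time of 72 h; on this read-out lower numbers stand for stronger inhibition and higher numbers for weaker inhibition.
Compound 2 `N#Cc1c(Nc2ccccc2Cl)nc(SCc2cn(Cc3ccccc3Cl)nn2)nc1-c1ccccc1` gives 8350 nM.
Compound 3 `N#Cc1c(Nc2ccccc2F)nc(SCc2cn(Cc3ccccc3Cl)nn2)nc1-c1ccccc1` gives 5230 nM.

Compound 3 stands second highest of the three numbers, and its distance to each neighbour is within the scatter: a 1.3-fold higher number from compound 1 to compound 3 (0.12 log units; within the scatter) and a 1.6-fold lower number from compound 2 to compound 3 (0.20 log units; within the scatter). Compound 4 `Cc1ccc(Cn2cc(CSc3nc(Nc4ccccc4F)c(C#N)c(-c4ccccc4)n3)nn2)cc1` differs from compound 3 by 4-methylphenyl in place of 2-chlorophenyl on a saturated chain carbon bound to an aromatic nitrogen. Among the measured compounds shown here, every measured step so far changes the group on the aromatic nitrogen instead, the largest being a 2.1-fold higher number from compound 1 to compound 2 (0.32 log units; beyond the scatter), and none touches the benzyl ring. For the measured compounds named here, no measured step therefore bears directly on this change, and the expectation is no step beyond the scatter: a 1.0-fold lower number from compound 3 to compound 4 (0.02 log units; within the scatter). Compound 4 is expected at 5000 nM, with a range from 2000 nM to 13000 nM.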

Compound 4, half-maximal inhibitory concentration: 16000 nM
Estimate against measurement, compound 4: 3.2-fold (0.51 log units) below; the whole stated range lies below it.
By their numbers in this assay, from the lowest: compounds 1, 3, 2 and 4 (each within the scatter of the next, the first and the last beyond it).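

The benzyl ring is not a silent part of these molecules: 4-methylbenzyl in place of 2-chlorobenzyl gives a 3.1-fold higher number from compound 3 to compound 4 (0.49 log units; beyond the scatter) and so weaker inhibition. This single step swaps chlorine for methyl and also moves the substituent around the ring, so it cannot show which of the two matters. Nothing available explains the step.

Going by these compounds, whether 4-chlorobenzyl or 2-methylbenzyl would separate these two changes remains open. So does how an unsubstituted benzyl group or a longer chain would behave at this position.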